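Compound 2 takes on a (4-methylphenyl)amino group

The compounds below may be only part of what the source reports. "The series", "measured", "known", "first", "only" and "open" are said of these compounds alone.

In a functional assay on A549 cells (Homo sapiens) for cytotoxicity, read by MTT assay, with a stated time of 48 h (a higher number here means a weaker inhibitor, a lower number a stronger inhibitor), compound 1 `C=C/C(C)=C\CC/C(C)=C/c1cc(C(=O)O)co1` gives 89300 nM and compound 2 `C=C/C(C)=C\CC/C(C)=C/c1cc(C(=O)OC)co1` gives 89600 nM. These two sit level, a 1.0-fold higher number from compound 1 to compound 2 (0.00 log units; within the scatter), and share the high end of the three numbers. Compound 3 `C=C/C(C)=C/CC/C(C)=C/c1cc(C(=O)OC)co1` gives 28600 nM, which is the lower number: a 3.1-fold lower number from compound 2 to compound 3 (0.50 log units; beyond the scatter), and the only structural difference behind this is the fact that compounds 2 and 3 differ only in the configuration as drawn.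

Compound 4 `C=C/C(C)=C\CC/C(C)=C/c1cc(C(=O)Nc2ccc(C)cc2)co1` carries (4-methylphenyl)amino in place of methoxy on a carbonyl carbon. Going by the values given here, only one measured step touches this carbonyl, and it offers a limited guide, as the exchange there left this assay unmoved, a 1.0-fold higher number from compound 1 to compound 2 (0.00 log units; within the scatter). The configuration step concerns another part of the molecule and says nothing direct about the new group. Yet the entering group is much larger than anything yet placed at this carbonyl, so a modest move towards a lower number is expected, though with wide uncertainty. The expected change is a 2.2-fold lower number from compound 2 to compound 4 (0.35 log units; beyond the scatter). For compound 4 the estimated value is 40000 nM, with an expected range from 14000 nM to 100000 nM.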

Compound 4, half-maximal inhibitory concentration: 63200 nM
For compound 4 the middle estimate is 1.6-fold (0.20 log units) below the measured one; the range from low to high includes it.
By their numbers in this assay, from the lowest: compound 3; then compounds 4, 1 and 2 (each within the scatter of the next).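

On the carbonyl carbon, the much larger (4-methylphenyl)amino group leaves this assay as unmoved as the earlier exchange there did: the steps are a 1.4-fold lower number from compound 2 to compound 4 (0.15 log units; within the scatter) and a 1.4-fold lower number from compound 1 to compound 4 (0.15 log units; within the scatter). Hydroxy, methoxy and (4-methylphenyl)amino therefore read level at this place, even though the entering group brings a six-membered aromatic ring and a hydrogen-bond donor, and the only step beyond the scatter among these compounds remains the double-bond configuration change between compound 2 and compound 3. Nothing measured here bears on why the number stays level through this exchange. Going by these compounds, it remains open whether (4-methylphenyl)amino would read the same on the double-bond configuration of compound 3. On these data alone, it is equally open whether a morpholine or a plain amino group on this carbonyl would depart from this level.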